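The compounds below may be only part of what the source reports. "The series", "measured", "known", "first", "only" and "open" are said of these compounds alone.

Working notes, activation series.

Of the compounds shown here, three have numbers so far in an assay on isolated protein for activation of Nicotinamide phosphoribosyltransferase (Homo sapiens); on this read-out lower numbers stand for an effect already at smaller amounts and higher numbers for an effect only at larger amounts of compound. Compound 1 `CCOC(=O)c1ccc(N/C(=N\C#N)NCc2ccncc2)cc1` gives 41400 nM. Compound 2 `CN(Cc1ccccc1)S(=O)(=O)c1ccc(NC(=O)NCc2ccncc2)cc1` gives 23 nM. Compound 3 `O=C(NCc1ccncc1)Nc1ccc(S(=O)(=O)c2cccc(Cl)c2)cc1` gives 69 nM. Among these three, compound 3 holds the second highest number: compound 2 lies nearest to it, and compound 1 lies furthest, with a gap that is clearly beyond the scatter.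

Going by the values given here, the only measured step that changes a group on the sulfonyl sulfur is a 3.0-fold higher number from compound 2 to compound 3 (0.48 log units; beyond the scatter), a modest shift that is beyond the scatter.

Compound 4 `O=C(NCc1ccncc1)Nc1ccc(S(=O)(=O)N2CC3CCC(C2)O3)cc1` has not been measured. Compared with compound 3 the change is a group of 8 heavy atoms (6 carbon, 1 nitrogen, 1 oxygen; one five-membered non-aromatic ring with 1 hetero atom, one six-membered non-aromatic ring with 2 hetero atoms) in place of a group of 7 heavy atoms (6 carbon, 1 chlorine; one six-membered aromatic ring of carbon only), on a sulfonyl sulfur. Among the compounds with values here, this step again exchanges the group on the sulfonyl sulfur, and the single comparable step, the one from compound 2 to compound 3, moved the number by a modest amount; compound 2 also carries a nitrogen on that sulfur, as compound 4 does. Within the data shown here, a modest shift toward a lower number is therefore expected, but with wide uncertainty, since only one step bears on it.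

The expected step is a 1.7-fold lower number from compound 3 to compound 4 (0.24 log units; within the scatter). For compound 4 the estimate in this assay is 40 nM, with a range from 10 nM to 150 nM.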

Compound 4, half-maximal effective concentration: 279 nM
The estimate for compound 4 lay 7.0-fold (0.84 log units) below the measured number, and the stated range ends below it.
By their numbers in this assay, from the lowest: compound 2; then compound 3; then compound 4; then compound 1.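

With three groups now read on the sulfonyl sulfur in this assay, a nitrogen attached to that sulfur clearly does not by itself place a compound at the low end of the series: a 12-fold higher number from compound 2 to compound 4 (1.08 log units; beyond the scatter), although both compounds carry such a nitrogen. The same exchange also separates the non-aromatic group from the 3-chlorophenyl group, with a 4.0-fold higher number from compound 3 to compound 4 (0.61 log units; beyond the scatter), so the new group stands above both earlier groups by steps beyond the scatter. Among these three compounds, which differ only on the sulfonyl sulfur, the two groups containing a six-membered aromatic ring of carbon only give the lower numbers, and the group with a five-membered and a six-membered non-aromatic ring gives the highest, although one such group is too little to show that non-aromatic groups in general behave this way.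

Nothing available explains the size or direction of these steps. From the compounds shown here alone, it remains open whether a morpholine or a piperidine on the sulfonyl sulfur would stand nearer compound 4 or compound 2, and so whether the higher number goes with the non-aromatic rings as such or with this particular two-ring group.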